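The source may hold more compounds than are shown below. What is called first, only, known or untested is meant among the compounds shown, and "the series" means these compounds.

Measured so far in an assay on HEK293 cells for inhibition of sodium-dependent dopamine transporter (Homo sapiens); on this read-out lower numbers stand for stronger inhibition and higher numbers for weaker inhibition:
Compound 1 `C=CCN(CCOC)C(=O)[C@@]1(c2ccsc2)C[C@H]1CN` gives > 10000 nM, a limit of the assay, not a number.
Compound 2 `C=CCN(C)C(=O)[C@@]1(c2ccsc2)C[C@H]1CN` gives > 10000 nM, likewise a limit.
Compound 3 `C=C(F)CN(C)C(=O)[C@@]1(c2ccsc2)C[C@H]1CN` gives > 10000 nM, likewise a limit.

Compound 2 and compound 1 differ by methoxymethyl in place of hydrogen on a saturated chain carbon bound to an amide-type nitrogen. The step that the two limits leave unreadable from compound 2 to compound 1 cannot be sized, because both values sit at the limit of > 10000 nM in this assay, at which 3 of the 3 values shown sit. Compound 4 `C=C(F)CN(CCOC)C(=O)[C@@]1(c2ccsc2)C[C@H]1CN` has not been measured; it differs from compound 3 by the same change, (methoxymethyl in place of hydrogen on a saturated chain carbon bound to an amide-type nitrogen), at a place described in the same words as for the earlier pair. The cores of the two pairs differ by fluoro in place of hydrogen on a double-bonded chain carbon bound to a saturated chain carbon. Among the compounds with values here, as every value so far rests at the limit of > 10000 nM in this assay, at which 3 of the 3 values shown sit, the step from compound 3 to compound 4 is expected to be about a step that the limit leaves unreadable from compound 3 to compound 4, no more readable than the earlier one. Compound 4 is accordingly estimated at 20000 nM, most likely reported again only as a limit.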

Compound 4, half-maximal inhibitory concentration: > 10000 nM
Compound 4: a limit, no number (the forecaster's own chance of this, stated with the estimate: 85%); the middle value lies beyond the limit too.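

Neither the step from compound 3 to compound 4 nor that from compound 1 to compound 4 can be read, because all four compounds rest at one limit: the limit of > 10000 nM in this assay, at which 4 of the 4 values shown sit.

The compounds shown leave open whether the methoxymethyl or the fluoro change alters the result in this assay at all.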